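The source may hold more compounds than are shown below. What is called first, only, known or untested is meant among the compounds shown, and "the series" means these compounds.

Compound 3 `O=C(Nc1ccc(Oc2ccnc3[nH]ccc23)cc1)c1cn(-c2ccc(Br)cc2F)c2ccccc2c1=O` gives 1330 nM in a functional assay on A549 cells (Homo sapiens) for inhibition, read by MTT assay, with a stated time of 72 h (on this read-out higher numbers stand for weaker inhibition and lower numbers for stronger inhibition), the highest of the three numbers; compound 1 `O=C(Nc1ccc(Oc2ccnc3[nH]ccc23)cc1)c1cn(-c2ccc(Cl)cc2)c2ccccc2c1=O` gives 650 nM and compound 2 `O=C(Nc1ccc(Oc2ccnc3[nH]ccc23)cc1)c1cn(-c2ccc(Br)cc2)c2ccccc2c1=O` gives 450 nM. Compound 4 `O=C(Nc1ccc(Oc2ccnc3[nH]ccc23)cc1)c1cn(-c2ccc(F)c(Cl)c2)c2ccccc2c1=O` differs from compound 3 by 3-chloro-4-fluorophenyl in place of 4-bromo-2-fluorophenyl on an aromatic nitrogen. Within the data shown here, two steps bear on it: a 3.0-fold higher number from compound 2 to compound 3 (0.47 log units; beyond the scatter), and a 1.4-fold lower number from compound 1 to compound 2 (0.16 log units; within the scatter). Compound 4 keeps a fluoro and a chloro, but as 3-chloro-4-fluorophenyl rather than the 4-bromo-2-fluorophenyl of compound 3, so the reading is uncertain: the number is expected to fall modestly, toward compound 1, with a 1.9-fold lower number from compound 3 to compound 4 (0.28 log units; within the scatter). Compound 4 is therefore estimated at 700 nM, within 300 nM to 1600 nM.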

Compound 4, half-maximal inhibitory concentration: 4810 nM
The estimate for compound 4 lay 6.9-fold (0.84 log units) below the measured number; measured number outside the range, above it.
By their numbers in this assay, from the lowest: compounds 2 and 1 (each within the scatter of the next); then compound 3; then compound 4.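

In this assay, among these compounds, the group on the aromatic nitrogen moves the number further than the earlier compounds showed, with a 3.6-fold higher number from compound 3 to compound 4 (0.56 log units; beyond the scatter) and a 7.4-fold higher number from compound 1 to compound 4 (0.87 log units; beyond the scatter) and the one large step, an 11-fold higher number from compound 2 to compound 4 (1.03 log units; beyond the scatter) on going to 3-chloro-4-fluorophenyl. Compound 3 and compound 4 both carry two halogens on this ring, yet they remain apart, so the halogen count alone does not set the number. Nothing available explains this rise. From the compounds shown here alone, it remains open whether the chloro or the fluoro of 3-chloro-4-fluorophenyl accounts for it, and how a phenyl bearing an amine or a carboxylic acid would read at this place.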